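A few compounds are considered here, and "the series" means these few. Any claim that something is new, unique, unknown or untested is made for them only; others in the source may bear on it.

Compound 1 `C=CCn1c(=O)/c(=C\c2cc(Br)ccc2F)[nH]c(=O)/c1=C\c1ccccc1OC` and compound 2 `C=CCn1c(=O)/c(=C\c2cc(F)ccc2C)[nH]c(=O)/c1=C\c1ccccc1OC` share one core and differ only in the aryl group on a double-bonded chain carbon bound to an aromatic carbon. In a functional assay on HL-60 cells (Homo sapiens) for cytotoxicity, read by CCK-8 assay, with a stated time of 72 h (on this read-out lower numbers stand for stronger inhibition and higher numbers for weaker inhibition), compound 1 gives 17400 nM, whereas compound 2 gives 2600 nM; the step of a 6.7-fold lower number from compound 1 to compound 2 (0.83 log units; beyond the scatter) shows that this aryl group moves the read-out well beyond the scatter. Among the measured compounds shown here, on the numbers so far, compound 2 stands lowest of the two.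

Compound 3 `C=CCn1c(=O)/c(=C\c2ccccc2F)[nH]c(=O)/c1=C\c1ccccc1OC` carries the change (2-fluorophenyl in place of 5-fluoro-2-methylphenyl on a double-bonded chain carbon bound to an aromatic carbon). For the measured compounds named here, only one measured step bears on it, a 6.7-fold lower number from compound 1 to compound 2 (0.83 log units; beyond the scatter), which concerns the same position but a different pair of aryl groups, so its direction cannot simply be carried over. Compound 3 is expected to land between the two measured numbers in this assay, a step of a 2.3-fold higher number from compound 2 to compound 3 (0.36 log units; beyond the scatter) being estimated. For compound 3 the estimate is 6000 nM, with a range from 2000 nM to 18000 nM.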

Compound 3, half-maximal inhibitory concentration: 18500 nM
Compound 3: middle estimate off by 3.1-fold (0.49 log units), on the low side; measured number above the stated range.
By their numbers in this assay, from the lowest: compound 2; then compounds 1 and 3 (each within the scatter of the next).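

In this assay the step of hydrogen in place of bromo on an aromatic carbon gives a 1.1-fold higher number from compound 1 to compound 3 (0.03 log units; within the scatter), so the bromo of compound 1 is not what sets it apart from compound 2 at this position. Exchanging 5-fluoro-2-methylphenyl for 2-fluorophenyl gives a 7.1-fold higher number from compound 2 to compound 3 (0.85 log units; beyond the scatter) and matches the earlier step in size, leaving compound 2 alone with the lower number among these three compounds. No measurement on hand offers an explanation for this difference.

Compound 2 differs from compound 3 in both the methyl group and the place of the fluorine, so the compounds shown do not assign the step to either one. They also leave open how this position would respond to a chloro, methoxy or trifluoromethyl group on the aryl ring.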